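The compounds below may be only part of what the source reports. "The series", "measured", "known", "first", "only" and "open" are said of these compounds alone.

Measured compounds and their values:

Compound 1, `Cc1cnc(Nc2ccc(S(C)(=O)=O)cc2)nc1Nc1nc2ccccc2s1` — in a functional assay on HCT-116 cells (Homo sapiens) for antiproliferative activity, read by MTT assay, with a stated time of 48 h (a lower number here means a stronger inhibitor, a higher number a weaker inhibitor), compound 1 gives 760 nM.
Compound 2, `NS(=O)(=O)c1ccc(Nc2ncc(F)c(Nc3nc4ccc(Cl)cc4s3)n2)cc1` — in this assay compound 2 gives 8620 nM.
Compound 3, `Cc1cnc(Nc2ccc(S(N)(=O)=O)cc2)nc1Nc1nc2ccccc2s1` — in this assay compound 3 gives 1660 nM.

Compound 2 has the highest number of the three, and its distance from both compound 3 and compound 1 lies beyond the usual scatter. Compound 3 and compound 1 share a core and differ in one place only: methyl in place of amino on a sulfonyl sulfur. That change gave a 2.2-fold lower number from compound 3 to compound 1 (0.34 log units; beyond the scatter), a modest step toward a stronger inhibitor.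

Compound 4, `CS(=O)(=O)c1ccc(Nc2ncc(F)c(Nc3nc4ccc(Cl)cc4s3)n2)cc1`, has not yet been measured in this assay. It is built from compound 2 by the same change: methyl in place of amino on a sulfonyl sulfur. The place is the same in both pairs, a sulfonyl sulfur whose other neighbour is an aromatic carbon, so this is the same change made on a different core. The difference between the core of compound 2 and the core of compound 3 is not broken down here. Within the data shown here, because the only example of this change is a 2.2-fold lower number from compound 3 to compound 1 (0.34 log units; beyond the scatter), the step from compound 2 to compound 4 is expected to be of a similar size, a 2.2-fold lower number from compound 2 to compound 4 (0.34 log units; beyond the scatter), resting on a single precedent on a different core and therefore uncertain. On that basis compound 4 is estimated to give 3900 nM in this assay, with a plausible range from 1500 nM to 10000 nM.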

Compound 4, half-maximal inhibitory concentration: 20700 nM
Estimate against measurement, compound 4: 5.3-fold (0.72 log units) below; the whole stated range lies below it.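

Replacing amino with methyl on the sulfonyl sulfur gave a 2.4-fold higher number from compound 2 to compound 4 (0.38 log units; beyond the scatter) in this assay, which means a weaker inhibitor, whereas the same replacement on the other core had given a stronger one. A step measured on one core therefore did not carry over to the other core in this series, not even in its direction, and the two results cannot be averaged into a single typical effect of the change: the same change on two cores in this assay, a 2.2-fold lower number (0.34 log units; beyond the scatter) from compound 3 to compound 1 and a 2.4-fold higher number (0.38 log units; beyond the scatter) from compound 2 to compound 4, 5.2-fold (0.72 log units) apart, beyond the scatter of two such steps

These two pairs do not show which part of the cores decides the direction of the step, and they say nothing about how the change would behave on a third core.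

Also open, going by these compounds, is how other groups on the sulfonyl sulfur would fare on these two cores, for example a longer chain such as ethyl, or a dimethylamino group in place of the plain amino. No pair shown changes the core while keeping the sulfonyl group fixed and differs in one place only, so the separate contribution of each difference between the two cores remains unknown.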